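A sulfonyl group replaces an amide on a shared core

This account rests on a few compounds, and the source may have more. Where it says the series, first, only, none or still open, it means among the compounds named here.

Of the compounds shown here, two on a shared core have been tested in a functional assay on DU-145 cells (Homo sapiens) for inhibition, read by trypan blue exclusion, with a stated time of 72 h; a higher number here means a weaker inhibitor, a lower number a stronger inhibitor. Compound 1 `Cn1c(=O)c(C(=O)Nc2ccc(F)cc2)cc2cnc(Nc3ccc4[nH]ccc4c3)nc21` carries a (4-fluorophenyl)carbamoyl group and in this assay gives 5000 nM. Compound 2 `Cn1c(=O)c(S(=O)(=O)c2ccc(F)cc2)cc2cnc(Nc3cccc4[nH]ccc34)nc21` gives 750 nM in this assay. Within the data shown here, of the two numbers known, compound 1 has the highest; the only other, that of compound 2, is lower by a gap beyond the usual scatter, so compound 1 is the weaker of the pair.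

Compound 3 `Cn1c(=O)c(S(=O)(=O)c2ccc(F)cc2N)cc2cnc(Nc3ccc4[nH]ccc4c3)nc21` has not yet been measured. It is built from compound 1 by one change: (2-amino-4-fluorophenyl)sulfonyl in place of (4-fluorophenyl)carbamoyl on an aromatic carbon. Among the measured compounds shown here, no measured pair shows this exact change on its own, so the size of the step in this assay cannot be read from the data. Because compound 2 gives 750 nM, a move toward a lower number for compound 3 is expected rather than none. On that basis compound 3 is estimated at 1200 nM, with a plausible range from 300 nM to 4500 nM, which would mean an expected step of a 4.2-fold lower number from compound 1 to compound 3 (0.62 log units; beyond the scatter).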

Compound 3, half-maximal inhibitory concentration: 3000 nM
Estimate against measurement, compound 3: 2.5-fold (0.40 log units) below, within the range that was stated.
By their numbers in this assay, from the lowest: compound 2; then compounds 3 and 1 (each within the scatter of the next).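

In this assay, putting (2-amino-4-fluorophenyl)sulfonyl in place of (4-fluorophenyl)carbamoyl on this aromatic carbon gives a 1.7-fold lower number from compound 1 to compound 3 (0.22 log units; within the scatter), so this assay cannot tell compound 1 and compound 3 apart. Among these compounds, this is the first direct reading at this position: a sulfonyl-linked ring carrying an amino group can stand where the amide-linked ring stood, with no step that rises above repeat-to-repeat noise, even though the two groups differ in their linker and in their counts of hydrogen-bond acceptors. Compound 2 differs from compound 3 in more than one place, so its value cannot be assigned to this position alone, and no measurement available here offers an explanation for the result.

The swap changes the linker and adds the amino group in a single step, leaving open what each part contributes on the core of compound 1. Also open, from the compounds shown here alone, is whether a hydroxyl or methoxy group in place of that amino group, or a carboxylic acid on the same ring, would give a number clearly separated from that of compound 3.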